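Branching at the chain carbon bound to the aromatic nitrogen

The source may report more compounds than this note shows. Statements on the series, on what has been measured and on what is new or still open speak of the compounds shown alone.

Going by the values given here, in an assay on Prostate gland for inhibition of steroid 5-alpha-reductase (Rattus norvegicus) (on this read-out higher numbers stand for weaker inhibition and lower numbers for stronger inhibition), compound 1 `CCCn1ccc2cc(/C(C)=C/C(=O)Nc3ccccc3OCCCC(=O)O)ccc21` gives 190 nM, the highest of the three numbers measured so far. Compound 2 `CCCCCCn1ccc2cc(/C(C)=C/C(=O)Nc3ccccc3OCCCC(=O)O)ccc21` gives 77 nM and compound 3 `CCCC(CC)n1ccc2cc(/C(C)=C/C(=O)Nc3ccccc3OCCCC(=O)O)ccc21` gives 9.3 nM. Compound 4 `CCCCC(CC)n1ccc2cc(/C(C)=C/C(=O)Nc3ccccc3OCCCC(=O)O)ccc21` is not yet measured; it differs from compound 1 by butyl in place of hydrogen on a saturated chain carbon bound to an aromatic nitrogen and a saturated chain carbon. Among the compounds with values here, the closest precedent is a 20-fold lower number from compound 1 to compound 3 (1.31 log units; beyond the scatter), the same kind of change at the same place with a chain one carbon shorter. Lengthening the chain at the aromatic nitrogen, in a 2.5-fold lower number from compound 1 to compound 2 (0.39 log units; beyond the scatter), also lowered the number, and an 8.3-fold lower number from compound 2 to compound 3 (0.92 log units; beyond the scatter) points the same way. A large drop is therefore expected. Compound 4 is estimated at 8 nM, in the range 3 nM to 25 nM, an expected step of a 24-fold lower number from compound 1 to compound 4 (1.38 log units; beyond the scatter).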

Compound 4, half-maximal inhibitory concentration: 7.1 nM
For compound 4 the middle estimate is 1.1-fold (0.05 log units) above the measured one, and the stated range covers the measured number.
By their numbers in this assay, from the lowest: compounds 4 and 3 (each within the scatter of the next); then compound 2; then compound 1.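

Butyl on the saturated chain carbon bound to an aromatic nitrogen and a saturated chain carbon also gives a large drop, with a 27-fold lower number from compound 1 to compound 4 (1.43 log units; beyond the scatter) in this series. Methyl in place of hydrogen four bonds along the chain from an aromatic nitrogen gives a 1.3-fold lower number from compound 3 to compound 4 (0.12 log units; within the scatter) and so shows no gain from this extra carbon. The branched chain again separates from the straight one, with an 11-fold lower number from compound 2 to compound 4 (1.04 log units; beyond the scatter) as a second such step.

Open, going by these compounds, is whether a longer chain on the branch, or a cyclohexyl group on the aromatic nitrogen, holds these numbers. Nothing given here bears on what lies behind the lower numbers of the branched chains.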